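The Mirror Image of Compound 1

The source may report more compounds than this note shows. Statements on the series, on what has been measured and on what is new or still open speak of the compounds shown alone.

Measured so far:
compound 1 `COc1ccc2c(c1O)O[C@@H](c1cccc(O)c1O)[C@H](O)C2=O` — 88500 nM
compound 2 `COc1ccc2c(c1)O[C@@H](c1cccc(O)c1O)[C@H](O)C2=O` — 30300 nM

In a functional assay on RAW264.7 cells (Rattus norvegicus) for inhibition, with RAW264.7 (Mus musculus) as the target, read by Griess assay, with stated times of 2 h and 16 h (on this read-out higher numbers stand for weaker inhibition and lower numbers for stronger inhibition), compound 1 gives 88500 nM, the highest of the two numbers measured. The nearest is compound 2, which gives 30300 nM; the change a 2.9-fold lower number from compound 1 to compound 2 (0.47 log units; beyond the scatter) goes with hydrogen in place of hydroxy on an aromatic carbon.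

Compound 3 `COc1ccc2c(c1O)O[C@H](c1cccc(O)c1O)[C@@H](O)C2=O` is built from the same atoms and bonds as compound 1: the two compounds have the same atoms and bonds and differ only in configuration as drawn: 2 of 2 stereo elements differ (all stereocentres are inverted: mirror images); a stereocentre at a saturated ring carbon is drawn S in compound 1 and R in compound 3; a stereocentre at a saturated ring carbon is drawn S in compound 1 and R in compound 3. The two compounds are mirror images of each other, and nothing else is changed.

For the measured compounds named here, only one measured step exists, and it replaces a group on an aromatic ring, so it says nothing about what happens when the configuration alone is inverted. Going by the values given here, no measured pair here differs in configuration. The step from compound 1 to compound 3 is therefore expected to be no change at the digits printed from compound 1 to compound 3 (within the scatter), with no direction that can be claimed beyond the scatter, and a wide range reflects that. For compound 3 the estimate in this assay is 88500 nM, expected to lie between 30000 nM and 260000 nM.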

Compound 3, half-maximal inhibitory concentration: 49700 nM
For compound 3 the middle estimate is 1.8-fold (0.25 log units) above the measured one; measured number inside the range.
By their numbers in this assay, from the lowest: compounds 2, 3 and 1 (each within the scatter of the next, the first and the last beyond it).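

In this assay, inverting both stereocentres together gives a 1.8-fold lower number from compound 1 to compound 3 (0.25 log units; within the scatter), so this assay does not separate compound 1 from its mirror image. For the compounds shown here, the only earlier step, a 2.9-fold lower number from compound 1 to compound 2 (0.47 log units; beyond the scatter), changed a group on an aromatic carbon and could say nothing about three-dimensional arrangement, whereas this pair gives the first direct reading of that arrangement at the two saturated ring carbons. The reading is a clean one, because no other structural change can enter the comparison: the fact that compounds 1 and 3 differ only in the configuration as drawn

From the compounds shown here alone, what happens when only one of the two stereocentres is inverted remains open, since that would give a compound that is not a mirror image of compound 1, and the same question stands for the mirror image of compound 2, whose hydrogen replaces the aromatic hydroxy of compound 1. Also open, going by these compounds, is how the numbers would respond to a different group on the saturated ring carbon that carries the hydroxy, such as an amine or a methoxy group, in either configuration.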